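A few compounds are considered here, and "the series" means these few. Any claim that something is new, unique, unknown or untested is made for them only; others in the source may bear on it.

Three compounds of this series have been run in a functional assay on HEK293 cells for agonist activity at D(4) dopamine receptor (Homo sapiens), read by FLIPR; on this read-out lower numbers stand for smaller maximal responses and higher numbers for larger maximal responses. For the measured compounds named here, compound 1 `CCc1cccc(NC(=O)CN2CCC(c3cccc[n+]3[O-])CC2)c1` gives 62%, the second highest of the three numbers so far. Compound 2 `O=C(NCN1CCC(c2cccc[n+]2[O-])CC1)c1ccccc1` gives 63%, which lies within the scatter of compound 1. Compound 3 `Cc1cccc(NC(=O)CN2CCC(c3cccc(F)c3)CC2)c1` gives 40%, a value below compound 1 and beyond the scatter. Compound 4 `Cc1cc(Br)ccc1NC(=O)CN1CCC(c2cccc[n+]2[O-])CC1` has not been measured. It differs from compound 1 in one place: 4-bromo-2-methylphenyl in place of 3-ethylphenyl on an amide-type nitrogen. Going by the values given here, no pair of measured compounds isolates this change, so nothing in the data sets its size or direction. The maximal response of compound 4 is expected to stay near that of compound 1, an expected step of a number 2 percentage points lower from compound 1 to compound 4 (within the scatter), not beyond the scatter. Compound 4 is estimated at 60%, in a range from 44% to 76%.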

Compound 4, largest response reached (reported as efficacy), in percent of the reference or control that the assay uses: 61%
Beside the measured number, compound 4's estimate is 1 percentage points below it; the range from low to high includes it.
By their numbers in this assay, from the lowest: compound 3; then compounds 4, 1 and 2 (each within the scatter of the next).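

In this assay, 4-bromo-2-methylphenyl in place of 3-ethylphenyl on the amide-type nitrogen gives a step of a number 1 percentage points lower from compound 1 to compound 4 (within the scatter). For the compounds shown here, this is the first pair that isolates this position, and it shows that the two differently substituted phenyl groups cannot be told apart on maximal response. Nothing available explains this result.

Only these two phenyl groups can be compared here, so the reach of this finding is open. A carboxylic acid or an amine on the phenyl ring, or a pyridine ring in its place, could still give a step beyond the scatter.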